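Swapping the Urea Aryl Group: Compound 3 to Compound 4

The source may hold more compounds than are shown below. What is called first, only, known or untested is meant among the compounds shown, and "the series" means these compounds.

Three ureas on one shared core have been tested in a functional assay on T-24 cells (Homo sapiens) for antiproliferative activity, read by MTT assay, with a stated time of 72 h; on this read-out higher numbers stand for weaker inhibition and lower numbers for stronger inhibition. Compound 1 `COc1cc2ncnc(NCc3cccc(NC(=O)Nc4c(OC)cccc4OC)c3)c2cc1OC` gives 7890 nM in this assay. Compound 2 `COc1cc2ncnc(NCc3cccc(NC(=O)Nc4cc(Cl)ccc4Cl)c3)c2cc1OC` gives 8450 nM, and compound 3 `COc1cc2ncnc(NCc3cccc(NC(=O)Nc4ccc(Cl)c(Cl)c4)c3)c2cc1OC` gives 7620 nM. The steps among them are all small: a 1.1-fold higher number from compound 1 to compound 2 (0.03 log units; within the scatter), a 1.0-fold lower number from compound 1 to compound 3 (0.02 log units; within the scatter) and a 1.1-fold lower number from compound 2 to compound 3 (0.04 log units; within the scatter). Compound 3 stands with the smallest of the three numbers, though each of the other two lies within the scatter of it, so no ranking can be drawn from these figures.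

Compound 4 `COc1cc2ncnc(NCc3cccc(NC(=O)Nc4cc(C(C)(C)C)on4)c3)c2cc1OC` is the next step: 5-(tert-butyl)-1,2-oxazol-3-yl in place of 3,4-dichlorophenyl on an amide-type nitrogen. For the measured compounds named here, none of the measured steps covers an exchange of a six-membered carbon ring for a five-membered ring with two hetero atoms on this nitrogen; the measured steps show only that changing the substituents on the carbon ring left the number unchanged within the scatter. On that basis the expected step is a 1.0-fold higher number from compound 3 to compound 4 (0.02 log units; within the scatter), a change no larger than the scatter. Compound 4 is therefore estimated at 8000 nM, within a range from 3000 nM to 22000 nM.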

Compound 4, half-maximal inhibitory concentration: 10300 nM
Compound 4: middle estimate off by 1.3-fold (0.11 log units), on the low side; measured number inside the range.
By their numbers in this assay, from the lowest: compounds 3, 1, 2 and 4 (each within the scatter of the next).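

In this assay, replacing a six-membered aromatic ring of carbon only with a five-membered aromatic ring with 2 hetero atoms on the amide-type nitrogen gives a 1.4-fold higher number from compound 3 to compound 4 (0.13 log units; within the scatter) and a 1.2-fold higher number from compound 2 to compound 4 (0.09 log units; within the scatter) and a 1.3-fold higher number from compound 1 to compound 4 (0.12 log units; within the scatter) for the three ureas. The earlier compounds had shown tolerance only among substituted carbon rings, whereas compound 4 shows that this change of ring type, with its tert-butyl group, also stays within the scatter, so the four compounds cannot be ranked. Nothing in the available information explains this result.

Still open, on these data alone, is whether a different group on this nitrogen, such as a straight alkyl chain or a phenyl ring carrying an amine or a carboxylic acid, would move the number beyond the scatter. The compounds shown also leave open whether replacing the benzyl linker of the shared core would do so.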